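The compounds below may be only part of what the source reports. "The series", "measured", "known", "first", "only" and "open" are said of these compounds alone.

Compound 3 `CN1CCC(C(=O)N2Cc3c(NC(=O)C4CC4)n[nH]c3C2(C)C)CC1` gives 1420 nM in a functional assay on A2780 cells (Homo sapiens) for antiproliferative activity, read by fluorescence, with a stated time of 72 h (on this read-out higher numbers stand for weaker inhibition and lower numbers for stronger inhibition), the highest number among the three measured compounds. Compound 1 `CN1CCC(C(=O)N2Cc3c(NC(=O)c4cc(F)cc(F)c4)n[nH]c3C2(C)C)CC1` gives 130 nM, and compound 2 `CN1CCC(C(=O)N2Cc3c(NC(=O)c4ccc(C(F)(F)F)cc4)n[nH]c3C2(C)C)CC1` gives 60 nM. The measured steps show an 11-fold higher number from compound 1 to compound 3 (1.04 log units; beyond the scatter) and a 24-fold higher number from compound 2 to compound 3 (1.37 log units; beyond the scatter), so in these three compounds an aromatic ring on the carbonyl carbon goes with much stronger inhibition than cyclopropyl, while the smaller step of a 2.2-fold lower number from compound 1 to compound 2 (0.34 log units; beyond the scatter) shows that the kind of aromatic ring matters less. Compound 4 `CN1CCC(C(=O)N2Cc3c(NC(=O)NCc4ccccc4)n[nH]c3C2(C)C)CC1` differs from compound 3 by benzylamino in place of cyclopropyl on a carbonyl carbon, which brings an aromatic ring back, though cut one bond further out the change reads cyclopropylcarbonyl to benzylcarbamoyl. Going by the values given here, no measured step covers that exact change. The expectation for compound 4 is therefore a lower number, a 4.7-fold lower number from compound 3 to compound 4 (0.68 log units; beyond the scatter), with less certainty than the aryl steps carry. Compound 4 is estimated at 300 nM, between 80 nM and 1200 nM.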

Compound 4, half-maximal inhibitory concentration: 2680 nM
Beside the measured number, compound 4's estimate is 8.9-fold (0.95 log units) below it; the measured number lies above the stated range.
By their numbers in this assay, from the lowest: compound 2; then compound 1; then compounds 3 and 4 (each within the scatter of the next).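

Adding an aromatic ring through benzylamino does not bring back the stronger inhibition: a 1.9-fold higher number from compound 3 to compound 4 (0.28 log units; within the scatter) is a step within the scatter, so the two compounds cannot be told apart. The steps of a 21-fold higher number from compound 1 to compound 4 (1.31 log units; beyond the scatter) and a 45-fold higher number from compound 2 to compound 4 (1.65 log units; beyond the scatter) show that, among these four compounds, strong inhibition goes only with a ring placed directly on the carbonyl carbon, not with any aromatic ring at this position. Nothing measured here accounts for this difference.

The compounds shown leave open whether the linking nitrogen or the extra carbon goes with the weaker inhibition. A phenylamino group and a benzyl group on the same carbonyl carbon would separate the two.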